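Replacing 1H-imidazol-1-yl with hydrogen in compound 2

A few compounds are considered here, and "the series" means these few. Any claim that something is new, unique, unknown or untested is made for them only; others in the source may bear on it.

In a functional assay on HCT-116 cells (Homo sapiens) for antiproliferative activity, read by MTT assay, with a stated time of 24 h (on this read-out lower numbers stand for stronger inhibition and higher numbers for weaker inhibition), compound 1 `COc1ccc(/C=C/C(=O)c2ccc(OC)c3c2OC(C)(C)C=C3)c(F)c1` gives > 10000 nM, which is a limit. Compound 2 `COc1ccc(C(=O)/C=C/c2ccc(-n3ccnc3)cc2)c2c1C=CC(C)(C)O2` gives > 10000 nM, also a limit, so it stands with no number. Compound 3 `COc1ccc(C(=O)/C=C/c2ccccc2)c2c1C=CC(C)(C)O2` has hydrogen in place of 1H-imidazol-1-yl on an aromatic carbon. No measured step sizes this change, and compound 1 and compound 2 offer only (the limit of > 10000 nM in this assay, at which 2 of the 2 values shown sit). No clear shift beyond the scatter is therefore expected in this assay, and a further limit is quite likely. The estimated step is a step that the limit leaves unreadable from compound 2 to compound 3. For compound 3 the expected value is 12000 nM, with an estimated range of 4000 nM to 40000 nM.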

Compound 3, half-maximal inhibitory concentration: > 10000 nM
Compound 3 ended at the assay's limit; the forecaster's own chance of this, stated with the estimate: 60%; the middle value does not contradict the limit.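

No step can be read among compound 1, compound 2 and compound 3 in this assay as all three stand at the same limit: the limit of > 10000 nM in this assay, at which 3 of the 3 values shown sit.
The compounds shown leave open how far each lies from that limit, and whether hydrogen or 1H-imidazol-1-yl on the aromatic carbon changes antiproliferative activity at all.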